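This account rests on a few compounds, and the source may have more. Where it says the series, first, only, none or still open, it means among the compounds named here.

Going by the values given here, compound 2 `CCCCCCCC/C=C\CCCCCCCCNC(=O)Nc1c(CC)cccc1C(C)C` gives the lowest of the two numbers so far in an assay on microsomes from intestinal mucosa for inhibition of acyl-CoA:cholesterol acyltransferase (Oryctolagus cuniculus) (on this read-out higher numbers stand for weaker inhibition and lower numbers for stronger inhibition), where compound 2 gives 37 nM. The other measured compound, compound 1 `CCCCCCCC/C=C\CCCCCCCCNC(=O)Nc1c(Cl)cccc1Cl`, gives 400 nM in this assay, and the step of an 11-fold lower number from compound 1 to compound 2 (1.03 log units; beyond the scatter) is large. Compound 3 `CCCCCCCCCCCCCCNC(=O)Nc1c(CC)cccc1C(C)C` differs from compound 2 by hexyl in place of dec-1-en-1-yl on a saturated chain carbon, eight bonds along the chain from an amide-type nitrogen. Among the compounds with values here, no measured step touches the chain, so the step from compound 1 to compound 2 bears on this change only as a sign that the shared core carries potency. Compound 3 is therefore expected to stay close to compound 2, with a step of a 1.6-fold higher number from compound 2 to compound 3 (0.21 log units; within the scatter) estimated and a value estimated at 60 nM, within 20 nM to 180 nM.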

Compound 3, half-maximal inhibitory concentration: 18 nM
Compound 3: the middle estimate sits 3.3-fold (0.52 log units) above what was measured; measured number outside the range, below it.
By their numbers in this assay, from the lowest: compound 3; then compound 2; then compound 1.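

Hexyl in place of dec-1-en-1-yl, eight bonds along the chain from an amide-type nitrogen, gives in this assay a 2.1-fold lower number from compound 2 to compound 3 (0.31 log units; beyond the scatter) and is a modest step. This shows that the chain itself can shift the number and that the dec-1-en-1-yl group with its double bond is not required for potency at this level. Nothing measured here accounts for the step. Loss of the double bond and shortening of the chain happen together in this one step, so their shares remain open. A saturated decyl group at this place would separate the two.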